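Swapping methyl for chloro in triazole-piperazine cytotoxicity series

The compounds below may be only part of what the source reports. "The series", "measured", "known", "first", "only" and "open" are said of these compounds alone.

Four compounds are compared in a functional assay on MCF7 cells (Homo sapiens) for cytotoxicity, read by MTT assay, with a stated time of 24 h; a higher number here means a weaker inhibitor, a lower number a stronger inhibitor. Compound 1 has the structure `Cc1ccc(-c2nnc(SCCCN3CCN(c4cccc(Cl)c4)CC3)[nH]2)cc1`. In this assay compound 1 reaches only a limit, reported as > 300000 nM. Compound 2, `Clc1ccc(-c2nnc(SCCCN3CCN(c4cccc(Cl)c4)CC3)[nH]2)cc1`, differs from it by the change (chloro in place of methyl on an aromatic carbon). In this assay compound 2 likewise reaches only a limit, > 300000 nM. The step that the two limits leave unreadable from compound 1 to compound 2 therefore cannot be read as a number, because the limit of > 300000 nM in this assay, at which 3 of the 3 values shown sit, sets the point at which both values sit.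

Compound 3, `Cc1ccc(-c2nn(CCCN3CCN(c4cccc(Cl)c4)CC3)c(=S)[nH]2)cc1`, carries the same atoms as compound 1 but joined differently; the difference between the two cores is not broken down here. In this assay compound 3 also gives only a limit, > 300000 nM.

Compound 4, `S=c1[nH]c(-c2ccc(Cl)cc2)nn1CCCN1CCN(c2cccc(Cl)c2)CC1`, is the not yet measured partner of compound 3 and differs from it by chloro in place of methyl on an aromatic carbon. This is the same change that separates compound 1 from compound 2, made on the core of compound 3, and the surroundings of the changed atom are described in the same words in both cases.

Since compound 1, compound 2 and compound 3 all sit at the limit described by the limit of > 300000 nM in this assay, at which 3 of the 3 values shown sit, the step from compound 3 to compound 4 is expected to be a step that the limit leaves unreadable from compound 3 to compound 4, that is, no readable movement. Compound 4 is accordingly estimated at 400000 nM, most probably reported again only as a limit, with a range from 150000 nM to 2000000 nM.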

Compound 4, half-maximal inhibitory concentration: > 300000 nM
Compound 4 gave a limit, no number; the forecaster's own chance of this, stated with the estimate: 85%; the middle value is on the limit's open side.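

No step can be read between compound 3 and compound 4, because each of them is reported only as a limit, not as a number, and the same is true of compound 1 and compound 2: the limit of > 300000 nM in this assay, at which 4 of the 4 values shown sit.

The compounds shown leave open whether 4-methylphenyl and 4-chlorophenyl differ at all in this assay, on either core, and whether the two cores themselves differ.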